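This account rests on a few compounds, and the source may have more. Where it says the series, first, only, none or still open, it means among the compounds named here.

In a functional assay on DU-145 cells (Homo sapiens) for inhibition, read by trypan blue exclusion, with a stated time of 96 h (a higher number here means a weaker inhibitor of growth, a lower number a stronger inhibitor of growth), three compounds built on a shared core have been measured. Compound 1 `COc1cc(/C=C(/Sc2ccc(Br)cc2)C(=O)c2ccc(Br)cc2)ccc1F` gives 10000 nM, compound 2 `O=C(/C(=C\c1ccc(Cl)c([N+](=O)[O-])c1)Sc1ccc(Br)cc1)c1ccc(Br)cc1` gives 10000 nM, and compound 3 `O=C(/C(=C\c1ccc(I)cc1)Sc1ccc(Br)cc1)c1ccc(Br)cc1` gives 1000 nM. This makes compound 3 the strongest growth inhibitor of the three, and its gap to each of the others lies beyond the usual scatter.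

The unmeasured compound 4 `O=C(/C(=C\c1ccc(Cl)cc1)Sc1ccc(Br)cc1)c1ccc(Br)cc1` differs from compound 3 in one place: chloro in place of iodo on an aromatic carbon. The halogen sits on an aromatic carbon, para to a large group, and 4-iodophenyl becomes 4-chlorophenyl.

Among the compounds with values here, only one measured step involves this part of the molecule: a 10-fold lower number from compound 1 to compound 3 (1.00 log units; beyond the scatter), with 4-iodophenyl in place of 4-fluoro-3-methoxyphenyl. That step is modest but beyond the scatter, so a change at this place can move the number. However, it is not a swap of one halogen for another, and no measured pair shows such a swap, which makes it only a loose guide. A smaller step is therefore expected, toward a higher number, with compound 3 already the lowest at 1000 nM. The expected outcome is a 2.5-fold higher number from compound 3 to compound 4 (0.40 log units; beyond the scatter). For compound 4 the estimated value is 2500 nM, with an expected range of 800 nM to 10000 nM.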

Compound 4, concentration for 50% growth inhibition: 1000 nM
Beside the measured number, compound 4's estimate is 2.5-fold (0.40 log units) above it; the measured number falls inside the stated range.
By their numbers in this assay, from the lowest: compounds 3 and 4 (each within the scatter of the next); then compounds 1 and 2 (each within the scatter of the next).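

In this assay, within the data shown here, chloro in place of iodo on this aromatic carbon gives no change at the digits printed from compound 3 to compound 4 (within the scatter) and is the first direct swap of one halogen for another at this place, so here the two halogens cannot be told apart. The number moves more when the rest of the ring changes: hydrogen in place of nitro gives a 10-fold lower number from compound 2 to compound 4 (1.00 log units; beyond the scatter), and 4-chlorophenyl in place of 4-fluoro-3-methoxyphenyl gives a 10-fold lower number from compound 1 to compound 4 (1.00 log units; beyond the scatter), so among these four compounds the two with a nitro or methoxy group on this ring have the higher numbers. Nothing shown here explains these steps.

The compounds shown leave open whether a group of another kind on this aromatic carbon, such as an amine or a carboxylic acid, would keep the number where compound 3 and compound 4 stand, or would move it as the nitro and methoxy changes do. They also leave open how the step from compound 1 divides between its methoxy group and its fluoro group, as the two change together in that pair.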